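A few compounds are considered here, and "the series" means these few. Any claim that something is new, unique, unknown or untested is made for them only; others in the source may bear on it.

Compound 1 `Cc1cc(OCc2ccc(F)cc2F)cc(=O)n1Cc1cn(Cc2cccc(Br)c2)nn1` was tested in an ADME assay on Vero cells (Chlorocebus sabaeus) for cytotoxicity (a higher number here means that more compound is tolerated, a lower number that less compound is tolerated), where compound 1 gives 36000 nM. Among the compounds with values here, this is the only value in this assay that is a full number rather than a limit. Compound 2 `COc1ccc(Cn2c(C)cc(OCc3ccc(F)cc3F)cc2=O)cc1` belongs to the same series. In this assay compound 2 gives < 4600 nM, which is a limit of the assay and not a measured number (the limit of < 4600 nM in this assay, at which 1 of the 2 values shown sits). The value of compound 2 is a limit. The two compounds cannot be placed in order against each other, and compound 1 stands alone as the reference point.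

Compound 3 `Cc1cc(OCc2ccc(F)cc2F)cc(=O)n1Cc1cn(Cc2cccc(C(F)(F)F)c2)nn1` has not yet been tested in this assay. It differs from compound 1 in one place: trifluoromethyl in place of bromo on an aromatic carbon. The bromo group on the aromatic carbon of the six-membered carbon ring is replaced by a trifluoromethyl group. Within the data shown here, since no pair of measured compounds shows the effect of this exchange, the expected step is small and is expected to stay within the usual scatter in either direction. The step from compound 1 to compound 3 is expected to be about a 1.2-fold lower number from compound 1 to compound 3 (0.08 log units; within the scatter). Compound 3 is therefore estimated to give 30000 nM, with a range from 12000 nM to 75000 nM.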

Compound 3, half-maximal cytotoxic concentration: 40000 nM
The estimate for compound 3 lay 1.3-fold (0.12 log units) below the measured number; measured number inside the range.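

Until now the series offered a single full number in this assay, so no change could be read as a step. The exchange of bromo for trifluoromethyl on this aromatic carbon of the benzyl group gives a 1.1-fold higher number from compound 1 to compound 3 (0.05 log units; within the scatter), and the two compounds therefore read as equal in this assay, even though the entering group has four heavy atoms where the leaving group has one. No measurement shown gives a reason for this outcome, and the one limit in the series does not bear on this exchange.

Bromo and trifluoromethyl both carry no hydrogen-bond donors or acceptors and no net charge, so it remains open whether the same position would read alike with an amine, a carboxylic acid or a longer chain such as a butyl group. Also open, as far as these compounds go, is whether this exchange would give the same result on another carbon of that ring, or on a compound with a different core.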